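Adding methoxy to the phenyl of compound 2

A few compounds are considered here, and "the series" means these few. Any claim that something is new, unique, unknown or untested is made for them only; others in the source may bear on it.

In a functional assay on M14 cells (Homo sapiens) for inhibition (on this read-out higher numbers stand for weaker inhibition of growth and lower numbers for stronger inhibition of growth), compound 1 (`COc1cc(/C=C/C(=O)c2cccc(-n3cc(-c4ccccc4)[nH]c3=O)c2)ccc1O`) gives 2610 nM and compound 2 (`COc1cc(/C=C/C(=O)c2cccc(-n3cc(-c4ccccc4)[nH]c3=O)c2)cc(OC)c1OC`) gives 1350 nM as its reading. Compound 2 therefore stands level with compound 1: the two numbers lie within the scatter of each other, and no ranking can be drawn from them.

The next compound is compound 3 (`COc1ccc(-c2cn(-c3cccc(C(=O)/C=C/c4cc(OC)c(OC)c(OC)c4)c3)c(=O)[nH]2)cc1`). Going by the values given here, its only difference from compound 2 is phenyl turned into 4-methoxyphenyl (methoxy in place of hydrogen on an aromatic carbon), which places methoxy in place of hydrogen on an aromatic carbon, para to a large group.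

Among the compounds with values here, no measured pair carries this change, so nothing yet shows its size directly. The expectation in this assay is a small step toward stronger inhibition of growth, possibly none beyond the scatter. Within the data shown here, the only anchor is compound 2 (1350 nM), and the range is kept wide for that reason. The expected step is a 1.2-fold lower number from compound 2 to compound 3 (0.09 log units; within the scatter) on this estimate. For compound 3 the estimated value is 1100 nM with 400 nM to 3000 nM as its expected range.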

Compound 3, concentration for 50% growth inhibition: 1850 nM
Compound 3: middle estimate off by 1.7-fold (0.23 log units), on the low side; low and high end bracket the measured number.
By their numbers in this assay, from the lowest: compounds 2, 3 and 1 (each within the scatter of the next).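

In this assay, methoxy in place of hydrogen on an aromatic carbon, para to a large group, gives a 1.4-fold higher number from compound 2 to compound 3 (0.14 log units; within the scatter). Going by these compounds alone, this is the first direct reading of this change, and it shows that this position of the phenyl can carry methoxy with a reading that cannot be told apart from the one with hydrogen, although this rests on a single pair. No measurement available for these compounds offers an explanation for this result.

The compounds shown leave open whether this position stays equally indifferent to groups of another kind, such as an amine, a carboxylic acid or an alkoxy group with a longer chain than methoxy, since only hydrogen and methoxy have been read here. Going by these compounds, it also remains open whether 4-methoxyphenyl in place of phenyl would give a level reading on compound 1, whose other aromatic ring is substituted differently, so the result cannot yet be carried beyond the background of compound 2.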